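Moving the furan attachment point in two related cores

The source may report more compounds than this note shows. Statements on the series, on what has been measured and on what is new or still open speak of the compounds shown alone.

Compound 1 `CCCOC(=O)C1=C(C)NC(=S)NC1c1ccco1` and compound 2 `CCCOC(=O)C1=C(C)NC(=S)NC1c1ccoc1` share one core and differ only in the furan ring. In an assay on membranes from HEK293 cells for displacement of a labelled ligand from adenosine receptor A2b (Homo sapiens), read by scintillation counting, with a stated time of 30 min, tested at 1 uM (on this read-out lower numbers stand for less inhibition and higher numbers for more inhibition at the one concentration tested (going by the name of the read-out)), compound 1 gives 46%, and compound 2 gives 45%. The change between them is furan-3-yl in place of furan-2-yl on a saturated ring carbon, and it made a number 1 percentage points lower from compound 1 to compound 2 (within the scatter).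

Compound 3 `COC(=O)C1=C(C)N(C)C(=O)NC1c1ccco1` is built on a second core; the difference between the two cores is not broken down here. In this assay compound 3 gives 31%, the lowest of the three measured numbers, and its steps to compound 2 and to compound 1 are both beyond the scatter.

Compound 4 `COC(=O)C1=C(C)N(C)C(=O)NC1c1ccoc1` has not yet been measured. It relates to compound 3 as compound 2 relates to compound 1: the change is furan-3-yl in place of furan-2-yl on a saturated ring carbon. The place of the change is described in nearly the same words in both pairs, but not word for word: in the first pair the saturated ring carbon is next to the ring atom that bears a propoxycarbonyl group, while in the second pair it is next to the ring atom that bears a methoxycarbonyl group and also three ring bonds from the ring atom that bears a methyl group. So this is the same kind of change, not the same change.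

Among the measured compounds shown here, because the only measured example of this change gave a number 1 percentage points lower from compound 1 to compound 2 (within the scatter), the step from compound 3 to compound 4 is expected to be small, about a number 1 percentage points lower from compound 3 to compound 4 (within the scatter). Compound 4 is therefore estimated to give about 30% in this assay. For the measured compounds named here, the expected range for compound 4 runs from 18% to 42%, resting on the single earlier step and on the different core.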

Compound 4, a percentage reported as inhibition, at one concentration (the size of the read-out at that concentration, not a potency): 7%
The estimate for compound 4 lay 23 percentage points above the measured number; measured number below the stated range.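

In this assay, furan-3-yl in place of furan-2-yl on the saturated ring carbon gave a number 24 percentage points lower from compound 3 to compound 4 (beyond the scatter), whereas the same swap made almost no difference on the core of compound 1. In this series, the effect of moving the furan attachment point therefore cannot be carried from one core to the other as a fixed amount, since its size differs between the two cores: the same change on two cores in this assay, a number 1 percentage points lower (within the scatter) from compound 1 to compound 2 and a number 24 percentage points lower (beyond the scatter) from compound 3 to compound 4, 23 percentage points apart, beyond the scatter of two such steps. Among the compounds shown here, this does not show which feature of the cores is responsible, as the two cores differ in more than one place, and with only two pairs, each read at a single concentration, it gives no general rule and no measure of potency.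

The compounds shown leave open whether the difference follows the ester, as only propoxycarbonyl on one core and methoxycarbonyl on the other appear here, or some other part of the core. They also leave open how the two furan attachments would compare with a butoxycarbonyl chain or a carboxylic acid in place of these esters, and whether an amine on the ring carbon in place of the furan would fit either core.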